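The source may hold more compounds than are shown below. What is called first, only, known or untested is meant among the compounds shown, and "the series" means these compounds.

Measured so far in a functional assay on PC-3 cells (Homo sapiens) for antiproliferative activity, read by sulforhodamine B assay, with a stated time of 96 h; on this read-out lower numbers stand for stronger inhibition and higher numbers for weaker inhibition:
- compound 1 `CN(C)c1ccc2c(c1)OC(N)=C(C#N)C2c1cccc2c(Br)cccc12` gives 390 nM
- compound 2 `COc1ccc(C2C(C#N)=C(N)Oc3cc(N(C)C)ccc32)c2ccccc12` gives 430 nM
- compound 3 `CN(C)c1ccc2c(c1)OC(N)=C(C#N)C2c1ccc(F)c2ccccc12` gives 640 nM

At 640 nM compound 3 stands level with the other two. Its value lies within the usual scatter of both compound 1 and compound 2, so these numbers cannot rank the three.

The next compound, compound 4 `CN(C)c1ccc2c(c1)OC(N)=C(C#N)C2c1ccc(N(C)C)c2ccccc12`, differs from compound 3 in one group only, as follows: dimethylamino in place of fluoro on an aromatic carbon and this exchange leaves dimethylamino para to a large group.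

Going by the values given here, one measured step bears on this carbon. That step, a 1.5-fold higher number from compound 2 to compound 3 (0.17 log units; within the scatter) with fluoro in place of methoxy on an aromatic carbon, stays within the scatter. Compound 1 is not linked to compound 3 by a change in one place, so it offers no direct guide. Exchanging the group at this carbon has so far shown no clear effect on the number, but that rests on a single pair, and no measured compound carries dimethylamino there.

No change beyond the scatter is therefore expected, and the range is kept wide. The expected step is a 1.3-fold lower number from compound 3 to compound 4 (0.11 log units; within the scatter) and it would leave the value close to those already seen. For compound 4 the estimated value is 500 nM with an expected range from 160 nM to 1600 nM in this assay.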

Compound 4, half-maximal inhibitory concentration: 220 nM
For compound 4 the middle estimate is 2.3-fold (0.36 log units) above the measured one; low and high end bracket the measured number.
By their numbers in this assay, from the lowest: compounds 4, 1, 2 and 3 (each within the scatter of the next, the first and the last beyond it).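

In this assay, going by these compounds alone, the carbon para to a large group now shows a change that goes beyond the usual scatter: dimethylamino in place of fluoro gives a 2.9-fold lower number from compound 3 to compound 4 (0.46 log units; beyond the scatter), a modest step, whereas the only earlier pair at this carbon stayed within the scatter. The position is therefore not indifferent to the group it carries, but the result does not set dimethylamino apart from every group tried there, since dimethylamino in place of methoxy gives a 2.0-fold lower number from compound 2 to compound 4 (0.29 log units; within the scatter), so these two groups cannot be ranked. Nothing measured here explains why the number moves with this exchange.

As far as these compounds go, with only fluoro, methoxy and dimethylamino compared at this carbon, it stays open whether the lower number belongs to dimethylamino in particular or would also appear with another nitrogen group, such as a plain amine or a pyrrolidine, while a carboxylic acid at the same carbon would show how far the number can move in the other direction. From the compounds shown here alone, it also stays open whether the same exchange would give a similar step on a core changed elsewhere, as all of these comparisons rest on one shared core.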